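Chain homologation on the sulfonamide nitrogen: compound 4

The source may hold more compounds than are shown below. What is called first, only, known or untested is meant among the compounds shown, and "the series" means these compounds.

Measured in a functional assay on OVCAR-5 cells (Homo sapiens) for inhibition; a lower number here means a stronger inhibitor of growth, a higher number a weaker inhibitor of growth:
compound 1 `Cc1c(C)c(S(=O)(=O)N(CCCN2C(=O)c3ccccc3C2=O)OCCCN2C(=O)c3ccccc3C2=O)c(C)c2c1OC(C)(C)CC2` gives 52500 nM
compound 2 `Cc1c(C)c(S(=O)(=O)N(CCCCCN2C(=O)c3ccccc3C2=O)OCCCN2C(=O)c3ccccc3C2=O)c(C)c2c1OC(C)(C)CC2` gives 52500 nM
compound 3 `Cc1c(C)c(S(=O)(=O)N(CCCCN2C(=O)c3ccccc3C2=O)OCCCN2C(=O)c3ccccc3C2=O)c(C)c2c1OC(C)(C)CC2` gives 52500 nM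

Compound 2 stands level with compound 1 and compound 3 in this assay, all three readings within the scatter of one another. Compound 4 `Cc1c(C)c(S(=O)(=O)N(CCCCCCN2C(=O)c3ccccc3C2=O)OCCCN2C(=O)c3ccccc3C2=O)c(C)c2c1OC(C)(C)CC2` extends the same chain by one step: a group of 12 heavy atoms (9 carbon, 1 nitrogen, 2 oxygen; one five-membered non-aromatic ring with 1 hetero atom, one six-membered aromatic ring of carbon only) in place of a group of 11 heavy atoms (8 carbon, 1 nitrogen, 2 oxygen; one five-membered non-aromatic ring with 1 hetero atom, one six-membered aromatic ring of carbon only), on a saturated chain carbon, five bonds along the chain from a sulfonamide nitrogen.

Going by the values given here, two measured steps bear on this change. Lengthening the chain gave no change at the digits printed from compound 1 to compound 3 (within the scatter) and shortening it gave no change at the digits printed from compound 2 to compound 3 (within the scatter); neither moved the read-out beyond the scatter. A further step of the same kind in compound 4 is therefore expected to give no change beyond the scatter, no change at the digits printed from compound 2 to compound 4 (within the scatter). Compound 4 is estimated at 52500 nM, with a range from 26000 nM to 105000 nM.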

Compound 4, concentration for 50% growth inhibition: 52500 nM
Estimate against measurement, compound 4: no gap at the digits printed; low and high end bracket the measured number.
By their numbers in this assay, from the lowest: compounds 1, 2, 3 and 4 (each within the scatter of the next).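

In this assay the flat read-out now extends to the position five bonds along the chain from a sulfonamide nitrogen: no change at the digits printed from compound 2 to compound 4 (within the scatter). Adding one more chain carbon therefore still has no effect beyond the scatter at this further length, and the two comparable steps agree: the same change on two cores in this assay, no change at the digits printed (within the scatter) from compound 1 to compound 3 and no change at the digits printed (within the scatter) from compound 2 to compound 4, 1.0-fold (0.00 log units) apart, within the scatter of two such steps

Still open, on these data alone, is whether a longer chain than in compound 4 would move the read-out. As far as these compounds go, it is also open whether an amine or a carboxylic acid in place of the group carried on this chain would do so.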